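A few compounds are considered here, and "the series" means these few. Any claim that something is new, unique, unknown or untested is made for them only; others in the source may bear on it.

Measured so far in a functional assay on KB cells (Homo sapiens) for cytotoxicity; a higher number here means a weaker inhibitor, a lower number a stronger inhibitor:
- compound 1, `N#Cc1cn(COCc2ccccc2)c2ncnc(N)c12`: > 100000 nM, a limit of the assay
- compound 2, `COCCOCn1cc(C(N)=S)c2c(N)ncnc21`: 183000 nM
- compound 3, `NC(=S)c1cn(COC(CO)CO)c2ncnc(N)c12`: > 100000 nM, a limit of the assay

Compound 3 stands at the limit of this assay. Only compound 2 gives a number, and that number sits close to the limit; the step that the limit leaves unreadable from compound 2 to compound 3 therefore cannot be read, and the limit of > 100000 nM in this assay, at which 2 of the 3 values shown sit, shows how little the series has resolved so far.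

The next compound is compound 4, `NC(=S)c1cn(COCc2ccccc2)c2ncnc(N)c12`. It differs from compound 3 by benzyl in place of 2-hydroxy-1-(hydroxymethyl)ethyl on an oxygen on a saturated carbon. Compound 4 is thus the thioamide counterpart of compound 1, which carries the same benzyl group and the same ether oxygen on a saturated carbon.

Within the data shown here, no measured step speaks directly to this change; compound 1 is at the limit, compound 3 is at the limit, and compound 2 lies near it. The account therefore expects no movement beyond the scatter: for compound 4 the estimated step is a step that the limit leaves unreadable from compound 3 to compound 4, and the estimate for compound 4 in this assay is 150000 nM, with a range from 60000 nM to 400000 nM, most likely reported again as a limit.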

Compound 4, half-maximal inhibitory concentration: > 100000 nM
Compound 4: a limit, no number (the forecaster's own chance of this, stated with the estimate: 70%); the middle value does not contradict the limit.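

Among these compounds, no step from compound 1, compound 2 or compound 3 to compound 4 can be read in this assay, where compound 4 gives only a limit, like most of the series: the limit of > 100000 nM in this assay, at which 3 of the 4 values shown sit. The compounds shown leave open whether exchanging benzyl for 2-hydroxy-1-(hydroxymethyl)ethyl, or changing the group on the aromatic carbon, alters the result in this assay at all.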